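This account rests on a few compounds, and the source may have more. Where it says the series, first, only, none or still open, it means among the compounds named here.

Three compounds have been measured in a functional assay on U-251 cells (Homo sapiens) for antiproliferative activity, read by MTT assay, with a stated time of 24 h; a lower number here means a stronger inhibitor, a higher number a weaker inhibitor:

compound 1, `C=CCOc1ccc2c(=O)c(-c3cc(OC)c(OC)cc3OC)coc2c1`, 5900 nM
compound 2, `COc1cc(OC)c(-c2coc3cc(OCc4ccccc4)ccc3c2=O)cc1OC`, 6750 nM
compound 3, `COc1cc(OC)c(-c2coc3cc(OCc4ccc(Br)cc4)ccc3c2=O)cc1OC`, 10000 nM

Compound 3 gives the highest of the three numbers, but the gaps are small: a 1.5-fold higher number from compound 2 to compound 3 (0.17 log units; within the scatter) and a 1.7-fold higher number from compound 1 to compound 3 (0.23 log units; within the scatter), so all three stand together within the scatter. The step from compound 1 to compound 2, a 1.1-fold higher number from compound 1 to compound 2 (0.06 log units; within the scatter), likewise changes nothing that can be told apart from repeat measurements.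

Compound 4, `COc1cc(OC)c(-c2coc3cc(OCc4ccc(Cl)cc4)ccc3c2=O)cc1OC`, has not yet been measured. It differs from compound 3 in one place: chloro in place of bromo on an aromatic carbon. Among the measured compounds shown here, the only measured step touching this position is the one from compound 2 to compound 3, a 1.5-fold higher number from compound 2 to compound 3 (0.17 log units; within the scatter), where bromo replaced hydrogen on an aromatic carbon. For the measured compounds named here, no measured pair compares a chloro with a bromo directly. Because that step was a 1.5-fold higher number from compound 2 to compound 3 (0.17 log units; within the scatter), the smaller swap of bromo for chloro is expected to move the number even less: no step beyond the scatter in either direction, a 1.1-fold lower number from compound 3 to compound 4 (0.05 log units; within the scatter). Compound 4 is therefore estimated at 9000 nM, between 4500 nM and 18000 nM.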

Compound 4, half-maximal inhibitory concentration: 470 nM
For compound 4 the middle estimate is 19-fold (1.28 log units) above the measured one, and the stated range ends above it.
By their numbers in this assay, from the lowest: compound 4; then compounds 1, 2 and 3 (each within the scatter of the next).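

In this assay, the group on the aromatic carbon para to a large group matters far more than the first three compounds suggested: exchanging one halogen atom for another, with the heavy-atom count unchanged, gives a 21-fold lower number from compound 3 to compound 4 (1.33 log units; beyond the scatter) while bromo in place of hydrogen had stayed within the scatter. Chloro also stands clearly apart from hydrogen at this place, with a 14-fold lower number from compound 2 to compound 4 (1.16 log units; beyond the scatter) as the step, and the full 4-chlorobenzyl group stands apart from the vinyl-bearing chain of the first compound, with a 13-fold lower number from compound 1 to compound 4 (1.10 log units; beyond the scatter) as the step, so compound 4 is the most potent of the four and the only one that separates from the rest. Nothing available here accounts for so large a gap between two single halogen atoms.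

The compounds shown leave open whether a fluoro, methyl or methoxy group at this same place would give a number near that of chloro or near those of hydrogen and bromo. They also leave open whether chloro would keep this gain on a different carbon of the ring, or on a longer chain between the ring and the oxygen.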